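Swapping 2-phenylethenyl for propyl on compound 1

A few compounds are considered here, and "the series" means these few. Any claim that something is new, unique, unknown or untested is made for them only; others in the source may bear on it.

Within the data shown here, in a functional assay (B cells) with Mus musculus as the target (on this read-out lower numbers stand for an effect already at smaller amounts and higher numbers for an effect only at larger amounts of compound), compound 1 `Nc1nc(O)c2c(n1)n(C1OC(CO)[C@@H](O)[C@H]1O)c(=O)n2C/C=C/c1ccccc1` gives 103 uM as the highest number of the three measured so far. Compound 2 `C=CCn1c(=O)n(CCCC)c2nc(N)nc(O)c21` gives 2 uM and compound 3 `C=CCn1c(=O)n(C2C=CC(CO)O2)c2nc(N)nc(O)c21` gives 6 uM without the 2-phenylethenyl group. Compound 4 `CCCCn1c(=O)n(C2OC(CO)[C@@H](O)[C@H]2O)c2nc(N)nc(O)c21` differs from compound 1 by propyl in place of 2-phenylethenyl on a saturated chain carbon bound to an aromatic nitrogen with propyl in place of 2-phenylethenyl on a saturated chain carbon bound to an aromatic nitrogen. Among the measured compounds shown here, no measured step makes this exact change. The closest evidence is a 3.0-fold higher number from compound 2 to compound 3 (0.48 log units; beyond the scatter) for a different group swap on an aromatic nitrogen, and that modest step is small beside the gap separating compound 1 from compound 2 and compound 3. A clearly lower number in this assay is therefore expected, though only loosely. The expected change is an 8.6-fold lower number from compound 1 to compound 4 (0.93 log units; beyond the scatter) in this estimate. Compound 4 is expected at 12 uM within an estimated range of 3 uM to 45 uM when measured.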

Compound 4, concentration for half-maximal effect: 11 uM
Compound 4: middle estimate off by 1.1-fold (0.04 log units), on the high side, within the range that was stated.
By their numbers in this assay, from the lowest: compound 2; then compounds 3 and 4 (each within the scatter of the next); then compound 1.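

In this assay, among these compounds, this is the first direct reading of a change to the chain on this aromatic nitrogen: propyl in place of 2-phenylethenyl gives a 9.4-fold lower number from compound 1 to compound 4 (0.97 log units; beyond the scatter). On this saturated chain carbon, therefore, the aromatic ring and the double bond outside it are not required for an effect, and the number falls when both leave together. No available measurement explains this step. The compounds shown leave open whether the ring or the double bond accounts for the change, as the two leave together. They also leave open how a longer chain, an amine or a carboxylic acid would read at this place.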